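The source may hold more compounds than are shown below. What is called first, only, known or untested is meant among the compounds shown, and "the series" means these compounds.

Compound 1 `O=C(O)[C@H](CO)NC(=O)[C@H]1C[C@H](O)CN1`: > 12 h
Compound 2 `O=C(O)[C@@H](CO)NC(=O)[C@H]1C[C@@H](O)CN1`: > 12 h
Compound 3 `O=C(N[C@H](CO)C(=O)O)[C@@H]1C[C@H](O)CN1`: > 12 h

In an ADME assay on Colon (Mus musculus, strain C57BL/6) for metabolic stability, read by HPLC, with a stated time of 12 h (on this read-out lower numbers stand for a shorter-lived compound and higher numbers for a longer-lived compound), compound 3 gives > 12 h, which is a limit of the assay and not a number. It stands with compound 1 and compound 2 at the limit of > 12 h in this assay, at which 3 of the 3 values shown sit.

Compound 4 `O=C(O)[C@H](CO)NC(=O)[C@@H]1C[C@H](O)CN1` has not been measured yet. It relates to compound 3 as follows: the two compounds have the same atoms and bonds and differ only in configuration as drawn: 1 of 3 stereo elements differ; a stereocentre at a saturated chain carbon is drawn R in compound 3 and S in compound 4. Nothing leaves and nothing enters, and a stereocentre at a saturated chain carbon is drawn R in compound 3 and S in compound 4.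

For the measured compounds named here, three measured steps bear on this, since each is a change of configuration alone: a step that the two limits leave unreadable from compound 1 to compound 2, a step that the two limits leave unreadable from compound 1 to compound 3 and a step that the two limits leave unreadable from compound 2 to compound 3. None has a readable size, and none changes the chain carbon on its own. They therefore give no sign of a step in either direction, but they cannot rule one out.

The expected result is that compound 4 stays close to the others, with any visible change more likely toward a shorter half-life. The step expected is a number no higher from compound 3 to compound 4 (the limit leaves the size open). For compound 4 the estimated half-life is 12 h, with an expected range from 3 h to 24 h.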

Compound 4, half-life: > 12 h
Compound 4: no number, only a limit; the forecaster's own chance of this, stated with the estimate: 60%; the middle value lies on the limit itself.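

For the compounds shown here, compound 4 ends at the same limit as compound 1, compound 2 and compound 3, so no step from any of these three to compound 4 can be read: the limit of > 12 h in this assay, at which 4 of the 4 values shown sit. The compounds shown leave open how long each one actually lasts, and whether any of these changes in configuration alters the half-life at all.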